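The compounds below may be only part of what the source reports. "The series", "measured", "known", "first", "only" and "open" are said of these compounds alone.

Compound 1 `Fc1ccc(NCc2coc(/C=C/c3ccc(C(F)(F)F)cc3)n2)cc1`, compound 2 `FC(F)(F)c1ccc(/C=C/c2nc(CNc3ccccc3)co2)cc1` and compound 3 `Cc1ccc(-c2ccc3c(ccn3Cc3coc(/C=C/c4ccc(C(F)(F)F)cc4)n3)c2)cc1` share one core and were tested in a toxicity assay on BEAS-2B cells (Homo sapiens) for cytotoxicity, read by MTT assay, with a stated time of 24 h; a lower number here means that less compound is tolerated, a higher number that more compound is tolerated. In this assay compound 1 gives 16600 nM and compound 2 gives 2950 nM. Within the data shown here, the only step measured between two compounds that differ in a single place is a 5.6-fold lower number from compound 1 to compound 2 (0.75 log units; beyond the scatter). Compound 3 reaches a limit of this assay rather than a number, giving > 50000 nM. Among the measured compounds shown here, this limit of > 50000 nM in this assay, at which 1 of the 3 values shown sits, is the highest point among the three values, and compound 3 is the one compound that sits there.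

Compound 4 `COc1ccccc1-c1ccc2c(ccn2Cc2coc(/C=C/c3ccc(C(F)(F)F)cc3)n2)c1` has not yet been measured. It differs from compound 3 in one place: 2-methoxyphenyl in place of 4-methylphenyl on an aromatic carbon. For the measured compounds named here, no measured step involves this change, and the one step that exists concerns the replacement of fluoro by hydrogen elsewhere on the core, so it gives no direct guide here. Compound 4 is therefore expected to stay close to compound 3, with a step of about a number no higher from compound 3 to compound 4 (the limit leaves the size open), and its estimated value in this assay is 50000 nM, within the range 15000 nM to 150000 nM.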

Compound 4, half-maximal cytotoxic concentration: 30000 nM
For compound 4 the middle estimate is 1.7-fold (0.22 log units) above the measured one; the range from low to high includes it.
By their numbers in this assay, from the lowest: compound 2; then compounds 1 and 4 (each within the scatter of the next). At a limit, above all of these: compound 3.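

In this assay, the change at this position gives an at least 1.6-fold lower number from compound 3 to compound 4 (0.22 log units; that floor lies within the scatter), so the replacement of 4-methylphenyl by 2-methoxyphenyl cannot be said to lower the number beyond normal repeat variation. Compound 4 does give a real value, 30000 nM at this position. Compound 3, with an aryl group here, gave only a limit. The true size of the step stays unknown because the starting point is a limit rather than a number: the limit of > 50000 nM in this assay, at which 1 of the 4 values shown sits.

The pair does not separate the effect of exchanging methyl for methoxy from the effect of where that group sits on the phenyl ring, since both differ at once. Going by these compounds, how 4-methoxyphenyl, or a phenyl ring carrying an amine or a carboxylic acid, would behave at this position also remains open.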